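Swapping the isoquinoline ether for a fused triazinone ether

A few compounds are considered here, and "the series" means these few. Any claim that something is new, unique, unknown or untested is made for them only; others in the source may bear on it.

Three compounds share the core of compound 1 `CC(C)[C@H](NC(=O)COc1cccc2ccccc12)C(=O)N[C@@H](CC(=O)O)C(=O)COc1nc2ccccc2[nH]1` and differ only in the aromatic group on an oxygen on a saturated carbon. In a functional assay on Jurkat cells (Homo sapiens) for inhibition (a lower number here means a stronger inhibitor, a higher number a weaker inhibitor), compound 1 gives only a limit of the assay, > 200000 nM. Compound 2 `CC(C)[C@H](NC(=O)COc1cccc2ccccc12)C(=O)N[C@@H](CC(=O)O)C(=O)COn1nnc2ccccc21` likewise gives only a limit in this assay, > 200000 nM. Within the data shown here, compound 3 `CC(C)[C@H](NC(=O)COc1cccc2ccccc12)C(=O)N[C@@H](CC(=O)O)C(=O)COc1nccc2ccccc12` is the one compound with a number in this assay, 106000 nM. Both steps toward it, an at least 1.8-fold lower number from compound 1 to compound 3 (0.27 log units; that floor lies within the scatter) and an at least 1.8-fold lower number from compound 2 to compound 3 (0.27 log units; that floor lies within the scatter), are floors whose size is hidden by the limit of > 200000 nM in this assay, at which 2 of the 3 values shown sit. Compound 4 `CC(C)[C@H](NC(=O)COc1cccc2ccccc12)C(=O)N[C@@H](CC(=O)O)C(=O)COn1nnc2ccccc2c1=O` carries a group of 11 heavy atoms (7 carbon, 3 nitrogen, 1 oxygen; one six-membered aromatic ring of carbon only, one six-membered aromatic ring with 3 hetero atoms) in place of a group of 10 heavy atoms (9 carbon, 1 nitrogen; one six-membered aromatic ring of carbon only, one six-membered aromatic ring with 1 hetero atom), on an oxygen on a saturated carbon. With only such floors to go on, the step of a 1.7-fold higher number from compound 3 to compound 4 (0.23 log units; within the scatter) is expected to run toward weaker inhibition, possibly back to the limit. Compound 4 is therefore estimated at 180000 nM in this assay, between 70000 nM and 400000 nM.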

Compound 4, half-maximal inhibitory concentration: 137000 nM
Compound 4: middle estimate off by 1.3-fold (0.12 log units), on the high side, within the range that was stated.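

In this assay, the step of a 1.3-fold higher number from compound 3 to compound 4 (0.11 log units; within the scatter) shows that a second group on this oxygen gives a number, and that a six-membered aromatic ring with 3 hetero atoms and a carbonyl can replace isoquinolin-1-yl with nothing beyond the scatter. Only floors link compound 4 to the other two compounds, an at least 1.4-fold lower number from compound 2 to compound 4 (0.16 log units; that floor lies within the scatter) and an at least 1.4-fold lower number from compound 1 to compound 4 (0.16 log units; that floor lies within the scatter), and both lie within the scatter. These floors do not show the true size of either step: the limit of > 200000 nM in this assay, at which 2 of the 4 values shown sit.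

The compounds shown leave open whether any group at this place moves the number beyond the scatter. A plain phenyl or a pyridine ring on the same oxygen would test this.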